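A few compounds are considered here, and "the series" means these few. Any claim that something is new, unique, unknown or untested is made for them only; others in the source may bear on it.

Measured compounds:
compound 1 `COc1cc2c(cc1OC)C(c1cccc(N)c1)=NN=C(S)C2`, 76.7 umol/kg
compound 2 `COc1cc2c(cc1OC)C(c1ccc(Cl)cc1)=NN=C(S)C2`, 193 umol/kg
compound 3 `COc1cc2c(cc1OC)C(c1ccc(Cl)cc1)=NNC(=O)C2`, 240 umol/kg

All three were tested in a functional assay on the whole organism with Mus musculus as the target, in the rotarod test; on this read-out higher numbers stand for an effect only at larger amounts of compound and lower numbers for an effect already at smaller amounts. Compound 1 and compound 2 share one core and differ by 3-aminophenyl in place of 4-chlorophenyl on a carbon with a double bond to nitrogen; that change gave a 2.5-fold lower number from compound 2 to compound 1 (0.40 log units; beyond the scatter). Compound 3 carries a different core; the difference between the two cores is not broken down here. Compound 4 `COc1cc2c(cc1OC)C(c1cccc(N)c1)=NNC(=O)C2` is the unmeasured partner of compound 3, differing from it by 3-aminophenyl in place of 4-chlorophenyl on a carbon with a double bond to nitrogen. The place of the change is described the same way for both pairs, except that for compound 2 it also lies three ring bonds from the ring atom that bears a sulfanyl group; so the change is the same kind of change, not the same. In this assay compound 3 gives 240 umol/kg, the highest number among the three. Because the earlier step was a 2.5-fold lower number from compound 2 to compound 1 (0.40 log units; beyond the scatter), a step of similar size, a 2.4-fold lower number from compound 3 to compound 4 (0.38 log units; beyond the scatter), is expected for compound 4. Compound 4 is therefore estimated at 100 umol/kg, with a range from 50 umol/kg to 220 umol/kg.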

Compound 4, dose for half-maximal effect: 51.5 umol/kg
Beside the measured number, compound 4's estimate is 1.9-fold (0.29 log units) above it; low and high end bracket the measured number.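

In this assay, 3-aminophenyl in place of 4-chlorophenyl on the second core gives a 4.7-fold lower number from compound 3 to compound 4 (0.67 log units; beyond the scatter). The number falls on both cores, and the two steps do not differ in size beyond what repeated measurement allows: the same change on two cores in this assay, a 2.5-fold lower number (0.40 log units; beyond the scatter) from compound 2 to compound 1 and a 4.7-fold lower number (0.67 log units; beyond the scatter) from compound 3 to compound 4, 1.9-fold (0.27 log units) apart, within the scatter of two such steps. Among these compounds, with only two pairs, this shows that the change carried over between these two cores in this read-out, but it does not show that it would do so on any other core, nor why the number falls.

The compounds shown leave open how a phenyl ring carrying a carboxylic acid or a nitrile would behave on either core. They also leave open what replacing the two methoxy groups with longer chains would do.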